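The source may report more compounds than this note shows. Statements on the series, on what has been measured and on what is new or still open speak of the compounds shown alone.

In a functional assay on DU-145 cells (Homo sapiens) for antiproliferative activity, read by fluorescence and propidium iodide staining, with a stated time of 96 h (on this read-out higher numbers stand for weaker inhibition and lower numbers for stronger inhibition), compound 1 (`CC(O)(CSc1cccc(C(F)(F)F)c1)C(=O)Nc1cc(C(F)(F)F)cc(C(F)(F)F)c1`) gives 10000 nM and compound 2 (`CC(O)(CSc1ccccc1C(F)(F)F)C(=O)Nc1cc(C(F)(F)F)cc(C(F)(F)F)c1`) gives 8660 nM. These two numbers lie within the scatter of each other, so compound 2 has no real edge over compound 1. Both compounds share a core and differ only in the aromatic group on the sulfur. That single measured step, 2-(trifluoromethyl)phenyl in place of 3-(trifluoromethyl)phenyl, is a 1.2-fold lower number from compound 1 to compound 2 (0.06 log units; within the scatter).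

Compound 3 (`CC(O)(CSc1cccc(OC(F)(F)F)c1)C(=O)Nc1cc(C(F)(F)F)cc(C(F)(F)F)c1`) keeps the same core and changes that group again, with 3-(trifluoromethoxy)phenyl in place of 2-(trifluoromethyl)phenyl on a sulfur. The sulfur's other neighbour remains a saturated chain carbon. For the measured compounds named here, no measured compound yet carries a trifluoromethoxy group, so the data give no direct evidence for this change. Going by the values given here, the only guide is the step from compound 1 to compound 2, which stayed within the scatter when this aromatic group was altered. The expected step is therefore small, with no direction favoured beyond the scatter: a 1.0-fold higher number from compound 2 to compound 3 (0.02 log units; within the scatter). For compound 3 the estimated value is 9000 nM, with an expected range from 3500 nM to 22000 nM.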

Compound 3, half-maximal inhibitory concentration: 9610 nM
For compound 3 the middle estimate is 1.1-fold (0.03 log units) below the measured one; the range from low to high includes it.
By their numbers in this assay, from the lowest: compounds 2, 3 and 1 (each within the scatter of the next).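

In this assay, the data now include a step that changes the group itself and not only where it is named on the ring: trifluoromethoxy in place of trifluoromethyl on an aromatic carbon is a 1.0-fold lower number from compound 1 to compound 3 (0.02 log units; within the scatter). The other new step, 3-(trifluoromethoxy)phenyl in place of 2-(trifluoromethyl)phenyl on a sulfur, is a 1.1-fold higher number from compound 2 to compound 3 (0.05 log units; within the scatter), so the entering oxygen and the hydrogen-bond acceptor counted with it do not set compound 3 apart from compound 1 or compound 2 on this read-out. No outside measurement is available to explain this result.

From the compounds shown here alone, all three compounds carry a fluorinated phenyl group on the sulfur, so it remains open whether a group of another kind there, such as an amine, a carboxylic acid or a longer alkyl chain, would give a number clearly apart from these. The shared core and the sulfur itself also stay the same throughout, which leaves open how far changes to either would move the numbers in this assay.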